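A few compounds are considered here, and "the series" means these few. Any claim that something is new, unique, unknown or untested is made for them only; others in the source may bear on it.

Of the compounds shown here, three have so far been tested in a functional assay on NCI-H460 cells (Homo sapiens) for antiproliferative activity, read by CCK-8 assay, with a stated time of 72 h, tested at 2 uM; on this read-out lower numbers stand for a weaker effect and higher numbers for a stronger effect at the one concentration tested. Compound 1 `CC(C)n1cnc2c(Nc3cccc(Cl)c3)nc(NCOCc3ccc(C(=O)Nc4ccccc4N)cc3)nc21` gives 28.9%. Compound 2 `Nc1ccccc1NC(=O)c1ccc(CNc2nc(Cl)nc3c2ncn3Cc2ccccc2)cc1` gives 43.8%, and compound 3 `CCCCn1cnc2c(Nc3cccc(Cl)c3)nc(NCOCc3ccc(/C=C/C(=O)Nc4ccccc4N)cc3)nc21` gives 25.7%. Compound 2 therefore stands highest of the three, and its margin over compound 1 and over compound 3 lies beyond the usual scatter of repeated measurements, so it counts as the strongest of the measured set.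

Compound 4 `CC(C)n1cnc2c(NCc3ccc(C(=O)Nc4ccccc4N)cc3)nc(Cl)nc21` has not yet been measured. It keeps the core of compound 2 and differs from it in one place: isopropyl in place of benzyl on an aromatic nitrogen. For the measured compounds named here, no step between two measured compounds covers this exact change on its own, so there is no measured guide to its size. Compound 1 also carries an isopropyl on that ring nitrogen, though it differs in other places too, and it gives 28.9%, a weaker effect than compound 2; that comparison spans more than one change and offers only a loose hint. A small fall, or none beyond the scatter, is expected for the step of a number 6.8 percentage points lower from compound 2 to compound 4 (within the scatter). Compound 4 is expected to give about 37% in this assay, with a likely range from 22% to 54%.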

Compound 4, a percentage reported as inhibition, at one concentration (the size of the read-out at that concentration, not a potency): 54.2%
The estimate for compound 4 lay 17.2 percentage points below the measured number; the whole stated range lies below it.
By their numbers in this assay, from the lowest: compounds 3 and 1 (each within the scatter of the next); then compound 2; then compound 4.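

In this assay, isopropyl in place of benzyl on the aromatic nitrogen of the five-membered ring gives a step of a number 10.4 percentage points higher from compound 2 to compound 4 (beyond the scatter) and so shows that the group at this position affects the read-out. The six-membered aromatic ring of benzyl is therefore not needed for activity on this core at the one concentration tested, since isopropyl, with no ring and fewer heavy atoms, gives the higher number. No measurement shown here explains the rise.

Going by these compounds, whether methyl, ethyl or cyclopentyl at this ring nitrogen would raise the number further remains open. For the compounds shown here, with only two groups compared at this position on the shared core, no trend with group size can be drawn, and it is unknown whether the same swap would help on other cores.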